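The source may hold more compounds than are shown below. What is called first, only, known or untested is meant among the compounds shown, and "the series" means these compounds.

Compound 1 `CCn1c(C(=O)NCC(=O)OC)ccc1C(CC)(CC)c1ccc(OCS(=O)(=O)c2ccccc2)c(C)c1`: > 50000 nM, a limit
Compound 2 `CCn1c(C(=O)NCCC(=O)OC)ccc1C(CC)(CC)c1ccc(OCS(=O)(=O)c2ccccc2)c(C)c1`: > 50000 nM, a limit
Compound 3 `CCn1c(C(=O)N[C@@H](CC(=O)OC)C(=O)OC)ccc1C(CC)(CC)c1ccc(OCS(=O)(=O)c2ccccc2)c(C)c1`: > 50000 nM, a limit

In a functional assay on MCF7 cells (Homo sapiens) for antiproliferative activity, read by MTT assay, with a stated time of 24 h (a higher number here means a weaker inhibitor, a lower number a stronger inhibitor), compound 3 gives > 50000 nM, which is a limit of the assay and not a number. It stands with the other two compounds: the limit of > 50000 nM in this assay, at which 3 of the 3 values shown sit.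

Compound 4 `CCN(CC)CCNC(=O)c1ccc(C(CC)(CC)c2ccc(OCS(=O)(=O)c3ccccc3)c(C)c2)n1CC` carries 2-(diethylamino)ethyl in place of 1,2-bis(methoxycarbonyl)ethyl on an amide-type nitrogen.

The measured steps bearing on this change are a step that the two limits leave unreadable from compound 1 to compound 2, a step that the two limits leave unreadable from compound 1 to compound 3 and a step that the two limits leave unreadable from compound 2 to compound 3. None has a readable size, and none brings in 2-(diethylamino)ethyl. Going by the values given here, no step of any particular size can therefore be expected in this assay, and a reading near the same limit seems likeliest.

The expected step is an at least 1.2-fold lower number from compound 3 to compound 4 (0.09 log units; that floor lies within the scatter). For compound 4 the estimate is 40000 nM, with an expected range of 10000 nM to 80000 nM.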

Compound 4, half-maximal inhibitory concentration: 4680 nM
The estimate for compound 4 lay 8.5-fold (0.93 log units) above the measured number, outside the stated range (below it).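

Going by these compounds alone, at this amide-type nitrogen, the groups carrying methoxycarbonyl gave no readable step, whereas 2-(diethylamino)ethyl gives the first real number in this assay. The change is large: an at least 10-fold lower number from compound 3 to compound 4 (1.02 log units; beyond the scatter), an at least 10-fold lower number from compound 2 to compound 4 (1.02 log units; beyond the scatter) and an at least 10-fold lower number from compound 1 to compound 4 (1.02 log units; beyond the scatter). The steps among compound 1, compound 2 and compound 3 cannot be read, and those compounds share one limit: the limit of > 50000 nM in this assay, at which 3 of the 4 values shown sit.

As far as these compounds go, it remains open whether the gain depends on the diethylamino group or simply on losing the methoxycarbonyl groups. A longer chain, a dimethylamino group or a morpholine at this place could separate these possibilities.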